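A few compounds are considered here, and "the series" means these few. Any claim that something is new, unique, unknown or untested is made for them only; others in the source may bear on it.

Measured compounds in a functional assay on HeLa cells (Homo sapiens) for antiproliferative activity, read by MTT assay, with a stated time of 48 h; a higher number here means a weaker inhibitor, a lower number a stronger inhibitor:

compound 1 `COc1ccc2c(/C=C/C(=O)c3cc(OC)c(OC)c(SC)c3)c[nH]c2c1`: 131 nM
compound 2 `COc1cc(C(=O)/C=C/c2c[nH]c3ccccc23)cc(SC)c1OC`: 159 nM
compound 3 `COc1cc(C(=O)/C=C/c2cn(C)c3ccccc23)cc([N+](=O)[O-])c1OC`: 1960 nM

Compound 2 and compound 1 differ in one place, (methoxy in place of hydrogen on an aromatic carbon). The step this change made in this assay, a 1.2-fold lower number from compound 2 to compound 1 (0.08 log units; within the scatter), is within the scatter, so the two values are read as equivalent. Compound 3 stands apart: its value is the highest of the three, and the difference between its core and the core of compound 2 is not broken down here; the numbers alone show a wide gap between them.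

Compound 4 `COc1ccc2c(/C=C/C(=O)c3cc(OC)c(OC)c([N+](=O)[O-])c3)cn(C)c2c1` has not yet been measured in this assay. It differs from compound 3 by methoxy in place of hydrogen on an aromatic carbon, the same change, at the same kind of place, that takes compound 2 to compound 1. For the measured compounds named here, since that earlier step a 1.2-fold lower number from compound 2 to compound 1 (0.08 log units; within the scatter) lay within the scatter, the step from compound 3 to compound 4 is expected to be small as well, about a 1.2-fold lower number from compound 3 to compound 4 (0.09 log units; within the scatter), on the single precedent available. Compound 4 is therefore estimated at 1600 nM in this assay, with a plausible range from 800 nM to 3500 nM.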

Compound 4, half-maximal inhibitory concentration: 951 nM
Estimate against measurement, compound 4: 1.7-fold (0.23 log units) above, and the stated range covers the measured number.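

In this assay methoxy in place of hydrogen on an aromatic carbon gives a 2.1-fold lower number from compound 3 to compound 4 (0.31 log units; beyond the scatter) on the core of compound 3, a modest step. Set beside the same change on the core of compound 2, the two steps cannot be told apart, so the change carries over between these two cores without a measurable difference in size: the same change on two cores in this assay, a 1.2-fold lower number (0.08 log units; within the scatter) from compound 2 to compound 1 and a 2.1-fold lower number (0.31 log units; beyond the scatter) from compound 3 to compound 4, 1.7-fold (0.23 log units) apart, within the scatter of two such steps. For the compounds shown here, this does not show that the change helps more on one core than on the other, even though only one of the two steps lies beyond the scatter, and two pairs give no rule for further cores or any reason for the size of the step.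

The compounds shown leave open what other groups would do at this place on the ring, such as a hydroxyl, a chlorine, an amine or a longer chain like ethoxy. They also leave open whether methoxy would give a similar step on another carbon of that ring.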